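Compound 1 and Its Terminal Alkyne Counterpart

The source may hold more compounds than are shown below. What is called first, only, known or untested is meant among the compounds shown, and "the series" means these compounds.

Measured in a functional assay on HCT-116 cells (Homo sapiens) for cytotoxicity, with a stated time of 3 days; a lower number here means a stronger inhibitor, a higher number a weaker inhibitor:
- Compound 1 `CC#CC1=Nc2ccccc2C(C)(C)O1`: > 40000 nM
- Compound 2 `Ic1nc2ccccc2o1`: > 40000 nM

Both entries are limits of the assay, not exact numbers. Going by the values given here, compound 1 therefore has no exact position on the scale, and the only evidence for it is the limit of > 40000 nM in this assay, at which 2 of the 2 values shown sit. Among the compounds with values here, compound 2 offers no structural step to compound 1 that could guide a prediction.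

The next compound is compound 3 `C#CC1=Nc2ccccc2C(C)(C)O1`, which has hydrogen in place of methyl on a triple-bonded carbon. In other words, prop-1-yn-1-yl becomes ethynyl. Within the data shown here, with no measured step to calibrate this change, only a modest shift towards stronger inhibition is expected, and another limit would be no surprise. The expected change, an at least 1.6-fold lower number from compound 1 to compound 3 (0.20 log units; that floor lies within the scatter), is therefore tentative. For compound 3, the estimated value in this assay is 25000 nM, with an expected range of 5000 nM to 40000 nM.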

Compound 3, half-maximal inhibitory concentration: 5610 nM
Compound 3: middle estimate off by 4.5-fold (0.65 log units), on the high side; measured number inside the range.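

Among the compounds shown, only compound 3 has an exact number, which shows that the group on this triple-bonded carbon can matter in this assay. Replacing methyl with hydrogen there gives an at least 7.1-fold lower number from compound 1 to compound 3 (0.85 log units; beyond the scatter), so even this small change moves the read-out beyond the usual scatter. Compound 1 is held only as a limit, > 40000 nM, so the step marks a minimum rather than an exact size, and limits are common in this small set: the limit of > 40000 nM in this assay, at which 2 of the 3 values shown sit.

From the compounds shown here alone, it remains open whether hydrogen is the best group at this place, or whether a phenyl ring, a hydroxymethyl group or a longer chain on the triple-bonded carbon would give a lower or a higher number. One step also cannot show whether the same change would hold on a different core.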